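From compound 2 to compound 3 at the limit

This account rests on a few compounds, and the source may have more. Where it says the series, first, only, none or still open, it means among the compounds named here.

In a functional assay on HUVEC cells (Homo sapiens) for antiproliferative activity, read by MTT assay, with a stated time of 24 h (on this read-out higher numbers stand for weaker inhibition and lower numbers for stronger inhibition), compound 1 (`COc1cc(OC)c(-c2coc3cc(OCc4ccc([N+](=O)[O-])cc4)ccc3c2=O)cc1OC`) gives > 10000 nM as its entry, which is a limit and not a number. Compound 2 (`COc1cc(OC)c(-c2coc3cc(OCc4ccccc4C(F)(F)F)ccc3c2=O)cc1OC`) also gives only a limit, > 10000 nM in this assay and no number. Among the compounds with values here, the series so far therefore offers a single piece of evidence, the limit of > 10000 nM in this assay, at which 2 of the 2 values shown sit, and nothing more.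

Compound 3 (`COc1cc(OC)c(-c2coc3cc(OCc4ccc(Cl)cc4)ccc3c2=O)cc1OC`) carries 4-chlorophenyl in place of 2-(trifluoromethyl)phenyl on a saturated chain carbon bound to an oxygen on an aromatic ring, and the count for this change is 4-chlorophenyl in place of 2-(trifluoromethyl)phenyl on a saturated chain carbon bound to an oxygen on an aromatic ring with the core unchanged.

Within the data shown here, the one measured step at this place is a step that the two limits leave unreadable from compound 1 to compound 2 and it provides neither a size nor a direction to carry over. The estimated change is a number no higher from compound 2 to compound 3 (the limit leaves the size open) and no step beyond the scatter is expected, although any real move could only be read toward stronger inhibition. For compound 3 the estimate is 10000 nM with an expected range from 2500 nM to 30000 nM and a report of a limit remains the likeliest outcome.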

Compound 3, half-maximal inhibitory concentration: 4400 nM
Beside the measured number, compound 3's estimate is 2.3-fold (0.36 log units) above it; measured number inside the range.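

In this assay, 4-chlorophenyl on a saturated chain carbon bound to an oxygen on an aromatic ring gives the series its first result that is a number rather than a limit, with an at least 2.2-fold lower number from compound 2 to compound 3 (0.35 log units; beyond the scatter) and an at least 2.2-fold lower number from compound 1 to compound 3 (0.35 log units; beyond the scatter). This place therefore responds to a change of aryl group beyond the scatter, and chloro in place of nitro on an aromatic carbon is enough to produce such a step, although both sizes are only lower bounds. The step from compound 1 to compound 2 cannot be read, and most of the series still rests on one shared limit: the limit of > 10000 nM in this assay, at which 2 of the 3 values shown sit.

On these data alone, the true size of both new steps remains open, and the two compounds at the limit cannot be placed in order. Also open, as far as these compounds go, is whether the step belongs to chloro alone, which would take an unsubstituted phenyl, a fluoro, or an amine or carboxylic acid on this ring to test, and whether a longer chain in place of the saturated chain carbon keeps the read-out of compound 3.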